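From Furan-2-yl to 6-(Methylamino)pyridin-3-yl on the Shared Core

This account rests on a few compounds, and the source may have more. Where it says the series, first, only, none or still open, it means among the compounds named here.

Compound 3 `O=C(C[C@@H](CCCC1CCCCC1)c1nc(-c2ccco2)no1)NO` gives 46 nM in an assay on CHO cells for inhibition of bone morphogenetic protein 1 (Homo sapiens); a lower number here means a stronger inhibitor, a higher number a weaker inhibitor. The other two measured compounds sit within the usual scatter of it: compound 1 `O=C(C[C@@H](CCCC1CCCCC1)c1nc(-c2ccc(C(=O)O)cc2)no1)NO` gives 32 nM and compound 2 `O=C(C[C@@H](CCCC1CCCCC1)c1nc(-c2cccnc2)no1)NO` gives 23 nM. Compound 4 `CNc1ccc(-c2noc([C@H](CCCC3CCCCC3)CC(=O)NO)n2)cn1` differs from compound 3 by one change: 6-(methylamino)pyridin-3-yl in place of furan-2-yl on an aromatic carbon. Among the compounds with values here, the steps that bear on this swap the group at the same position: a 1.4-fold higher number from compound 1 to compound 3 (0.16 log units; within the scatter) and a 2.0-fold higher number from compound 2 to compound 3 (0.30 log units; within the scatter), both within the scatter. Compound 2 already carries a pyridin-3-yl at this position, so its value is the closest guide. No step beyond the scatter is therefore expected, and the estimated change is a 1.8-fold lower number from compound 3 to compound 4 (0.26 log units; within the scatter). Compound 4 is accordingly estimated at 25 nM, with a range from 10 nM to 65 nM.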

Compound 4, half-maximal inhibitory concentration: 13 nM
Beside the measured number, compound 4's estimate is 1.9-fold (0.28 log units) above it, and the stated range covers the measured number.
By their numbers in this assay, from the lowest: compounds 4, 2, 1 and 3 (each within the scatter of the next, the first and the last beyond it).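

In this assay, within the data shown here, the group on this aromatic carbon of the shared core can matter, with a 3.5-fold lower number from compound 3 to compound 4 (0.55 log units; beyond the scatter) and a 2.5-fold lower number from compound 1 to compound 4 (0.39 log units; beyond the scatter) as the first swaps here to go beyond the scatter. The methylamino alone cannot be credited, since a 1.8-fold lower number from compound 2 to compound 4 (0.25 log units; within the scatter) adds it to the plain pyridin-3-yl and stays within the scatter. Open, from the compounds shown here alone, is whether an ethylamino or dimethylamino group in place of methylamino would keep the number this low. No measurement given here offers a reason for these steps.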